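Fluoro to Methyl: A Small Change on a Shared Core

The compounds below may be only part of what the source reports. "The series", "measured", "known", "first", "only" and "open" are said of these compounds alone.

Of the compounds shown here, three have been tested in a functional assay on HTB-54 cells (Homo sapiens) for cytotoxicity, read by MTT assay, with a stated time of 72 h; a lower number here means a stronger inhibitor of growth, a higher number a weaker inhibitor of growth. Compound 1 `N#C[Se]c1ccc(NC(=O)OCc2ccc([N+](=O)[O-])cc2)cc1` gives 47600 nM, compound 2 `N#C[Se]c1ccc(NC(=O)Oc2ccc(F)cc2)cc1` gives 48400 nM, and compound 3 `CCCCOC(=O)Nc1ccc([Se][Se]c2ccc(NC(=O)OCCCC)cc2)cc1` gives 57300 nM. Compound 2 has the second highest of these three numbers, yet its gaps to compound 1 and to compound 3 both fall within the usual scatter, so the three behave alike here. Compound 4 `Cc1ccc(OC(=O)Nc2ccc([Se]C#N)cc2)cc1` differs from compound 2 by one small change: methyl in place of fluoro on an aromatic carbon. Going by the values given here, no measured pair shows what methyl in place of fluoro on an aromatic carbon does in this assay; the step is therefore expected to be small, in no particular direction, and likely within the scatter. Compound 4 is expected to give about 50000 nM, between 25000 nM and 100000 nM. The expected step is a 1.0-fold higher number from compound 2 to compound 4 (0.01 log units; within the scatter).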

Compound 4, concentration for total growth inhibition: 44200 nM
The estimate for compound 4 lay 1.1-fold (0.05 log units) above the measured number, and the stated range covers the measured number.
By their numbers in this assay, from the lowest: compounds 4, 1, 2 and 3 (each within the scatter of the next).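

In this assay, going by these compounds alone, the swap of fluoro for methyl on this aromatic carbon, para to a large group, gives a 1.1-fold lower number from compound 2 to compound 4 (0.04 log units; within the scatter) and is the first measured pair here that differs in one place. At this spot, the two groups cannot be told apart in this assay. Nothing measured here bears on why the step is so small.

On these data alone, whether an amine, a carboxylic acid or a longer chain at the same carbon would give a step beyond the scatter remains open. As far as these compounds go, whether methyl in place of fluoro acts the same way on other aromatic carbons also remains open.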